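A few compounds are considered here, and "the series" means these few. Any claim that something is new, unique, unknown or untested is made for them only; others in the source may bear on it.

Values measured in a functional assay on PC-3 cells (Homo sapiens) for cytotoxicity, read by MTT assay, with a stated time of 24 h (on this read-out lower numbers stand for stronger inhibition and higher numbers for weaker inhibition), are these:

Compound 1 `COc1ccc(/C=C2\CN(C(=S)SCc3cn(Cc4ccc(F)cc4)nn3)C/C(=C\c3ccc(OC)cc3)C2=O)cc1` gives 45600 nM
Compound 2 `O=C1/C(=C/c2ccccc2F)CN(C(=S)SCc2cn(Cc3ccccc3Cl)nn2)C/C1=C\c1ccccc1F` gives > 80000 nM

Compound 2 has no exact number in this assay since its entry of > 80000 nM is a limit of the assay. Compound 3 `O=C1/C(=C/c2ccccc2F)CN(C(=S)SCc2cn(Cc3ccccc3F)nn2)C/C1=C\c1ccccc1F` keeps the shared core of compound 2 and alters only the benzyl group, where 2-chlorobenzyl becomes 2-fluorobenzyl: fluoro in place of chloro on an aromatic carbon with fluoro in place of chloro on an aromatic carbon. Within the data shown here, no measured pair shows this swap, so only a small gain toward stronger inhibition is expected in this assay and perhaps none beyond the scatter. Among the measured compounds shown here, compound 1 gives 45600 nM as the only exact number, so a value for compound 3 is expected to stay weak. The estimate means an at least 1.1-fold lower number from compound 2 to compound 3 (0.05 log units; that floor lies within the scatter) as an expected step. Expected for compound 3 is 70000 nM within an estimated range from 30000 nM to 130000 nM in this read-out.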

Compound 3, half-maximal inhibitory concentration: > 80000 nM
Compound 3: a limit, no number; the forecaster's own chance of this, stated with the estimate: 50%; at least 1.1-fold (0.05 log units) between middle value and limit.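

In this assay, among these compounds, compound 3 gives > 80000 nM as a limit of the assay, not a number, and no step from compound 2 can be read, since both compounds sit at that limit: the limit of > 80000 nM in this assay, at which 2 of the 3 values shown sit. The compounds shown leave open whether fluoro in place of chloro on the benzyl group changes cytotoxicity at all.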